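Benzyl group variation across compounds 1 to 4

This account rests on a few compounds, and the source may have more. Where it says the series, first, only, none or still open, it means among the compounds named here.

Measured so far in a functional assay on SW480 cells (Homo sapiens) for cytotoxicity, read by MTT assay, with a stated time of 48 h; a lower number here means a stronger inhibitor, a higher number a weaker inhibitor:
compound 1, `Cc1ccccc1Cn1cc(COc2ccc3c(=O)ccoc3c2)nn1`, gives > 100000 nM
compound 2, `O=c1ccoc2cc(OCc3cn(Cc4ccc(F)cc4)nn3)ccc12`, gives 11200 nM
compound 3, `CC(C)(C)c1ccc(Cn2cc(COc3ccc4c(=O)ccoc4c3)nn2)cc1`, gives 28800 nM

The value of compound 1 is a limit of this assay, not a number (the limit of > 100000 nM in this assay, at which 1 of the 3 values shown sits). Among the two real numbers, compound 2 stands lowest; compound 3 is its nearest neighbour, a 2.6-fold higher number from compound 2 to compound 3 (0.41 log units; beyond the scatter). The step of an at least 8.9-fold lower number from compound 1 to compound 2 (0.95 log units; beyond the scatter) is at least modest, so the benzyl substituent clearly matters in this assay.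

Compound 4, `O=c1ccoc2cc(OCc3cn(Cc4ccccc4Br)nn3)ccc12`, is not yet measured. It differs from compound 2 in one place: 2-bromophenyl in place of 4-fluorophenyl on a saturated chain carbon bound to an aromatic nitrogen. Within the data shown here, two measured steps bear on it. The step of an at least 8.9-fold lower number from compound 1 to compound 2 (0.95 log units; beyond the scatter) shows that a 2-substituted benzyl, with methyl, sits at the limit while the 4-fluoro analogue is measurable, and the step of a 2.6-fold higher number from compound 2 to compound 3 (0.41 log units; beyond the scatter) shows that even a change of substituent at the same ring position moves the number by a modest amount. Compound 4 carries its substituent at the ring position of compound 1, so a higher number than compound 2 is expected, with a fair chance that only a limit is reported. The expected step is a 4.5-fold higher number from compound 2 to compound 4 (0.65 log units; beyond the scatter). The estimate for compound 4 is 50000 nM, within 15000 nM to 150000 nM.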

Compound 4, half-maximal inhibitory concentration: > 100000 nM
Compound 4 ended at the assay's limit; the forecaster's own chance of this, stated with the estimate: 35%; middle value at least 2.0-fold (0.30 log units) from the limit.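

In this assay, the change from 4-fluorobenzyl to 2-bromobenzyl gives an at least 8.9-fold higher number from compound 2 to compound 4 (0.95 log units; beyond the scatter), so the loss seen with the 2-methylphenyl group of compound 1 is not confined to methyl. Compound 1 and compound 4, the two compounds here with a 2-substituted benzyl, each give a limit and not a number: the limit of > 100000 nM in this assay, at which 2 of the 4 values shown sit. The step between compound 1 and compound 4 cannot be read, so bromo and methyl stay unranked, while the link between a 2-substituted benzyl and a limit holds across these four compounds, with none going against it.

The change in compound 4 alters both the halogen and its place on the ring, and the compounds shown do not separate the two; a 2-fluorobenzyl or a 4-bromobenzyl group would do so. Also open, on these data alone, is whether any 2-substituted benzyl can return a real number in this assay, for example one carrying an amine or a carboxylic acid in place of the bromo of compound 4.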